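The compounds below may be only part of what the source reports. "The series", "measured", "known", "first", "only" and "open" are said of these compounds alone.

Of the compounds shown here, two have so far been measured in a functional assay on the whole organism for inhibition, with Rattus norvegicus as the target, with a stated time of 5 min, at a dose of 3 mg/kg by the oral route; on this read-out higher numbers stand for more inhibition at the one dose given (going by the name of the read-out) and lower numbers for less inhibition. Compound 1, with the structure `CCc1ccnc(C(=O)Nc2nn[nH]n2)c1`, gives 54% in this assay. Compound 2, with the structure `Cc1cccc(C(=O)Nc2nn[nH]n2)n1`, gives 73% in this assay. Of these two numbers, compound 2 stands highest, and the gap down to compound 1 lies beyond the usual scatter, so the inhibition in this assay is higher for compound 2 than for compound 1. For the measured compounds named here, no two measured compounds differ in only one place, so no single structural change has yet been tied to a step in the numbers.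

Compound 3, with the structure `Cc1cc(Cl)cc(C(=O)Nc2nn[nH]n2)n1`, has not been measured. It differs from compound 2 in one place: chloro in place of hydrogen on an aromatic carbon. Going by the values given here, since no measured step involves a change of this kind, the data give no direction to expect; the expected step is a number 3 percentage points lower from compound 2 to compound 3 (within the scatter), that is, nothing beyond the usual scatter in this assay, with a wide range on either side to allow for a real shift in either direction. Compound 3 is therefore expected to give 70% in this assay, with a range from 45% to 90%.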

Compound 3, a percentage reported as inhibition, in the whole organism at one dose (the size of the read-out at that dose, not a potency): 85%
Compound 3: the middle estimate sits 15 percentage points below what was measured, and the stated range covers the measured number.
By their numbers in this assay, from the lowest: compound 1; then compound 2; then compound 3.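

In this assay, for the compounds shown here, chloro in place of hydrogen on the aromatic carbon opposite the ring nitrogen gives a number 12 percentage points higher from compound 2 to compound 3 (beyond the scatter), and this is the first step here that can be tied to a single structural change. It shows that this position, meta to the methyl group and meta to the group of 8 heavy atoms, accepts a chlorine atom without any loss of inhibition, and that the change in fact goes with a modest real gain. As the read-out gives the size of the effect at one oral dose, this gain is a gain at that dose and not a measured gain in potency, and no measurement at hand bears on why the number rises.

Going by these compounds alone, the single step leaves open whether the gain is specific to chloro or would also appear with another group on the same carbon, such as fluoro, methoxy or an amine. It also leaves open whether chloro at this position would give a similar step on a different parent, such as one carrying a longer chain in place of the methyl group.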